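A few compounds are considered here, and "the series" means these few. Any claim that something is new, unique, unknown or untested is made for them only; others in the source may bear on it.

Working notes on the series. Compound 2 `COc1cc(-c2cc(/C=C/C(=O)c3ccc(N)cc3)[nH]n2)cc(OC)c1OC` gives -98% in a functional assay on HOP-62 cells (Homo sapiens) for cytotoxicity, read by sulforhodamine B assay, with a stated time of 48 h, tested at 100 uM (on this read-out higher numbers stand for a weaker effect at the one concentration tested and lower numbers for a stronger effect), the lowest of the three numbers in hand. Compound 1 `COc1ccc(-c2cc(/C=C/C(=O)c3ccc(N)cc3)[nH]n2)cc1` gives -60% in this assay, and compound 3 `COc1ccc(C(=O)/C=C/c2cc(-c3cc(OC)c(OC)c(OC)c3)n[nH]2)cc1` gives -79%. For the measured compounds named here, the only measured single step, a number 19 percentage points higher from compound 2 to compound 3 (beyond the scatter), concerns the amino group rather than the methoxy pattern. Compound 4 `COc1ccc(-c2cc(/C=C/C(=O)c3ccc(N)cc3)[nH]n2)cc1OC` differs from compound 2 as hydrogen in place of methoxy on an aromatic carbon. Going by the values given here, no measured step removes a methoxy group; compound 1 and compound 2, which differ in two methoxy groups, show a weaker read-out for compound 1. Compound 4 is therefore expected to sit between those two, a step of a number 18 percentage points higher from compound 2 to compound 4 (beyond the scatter) toward weaker effect. The estimate for compound 4 is -80%, within -100% to -55%.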

Compound 4, a percentage reported as activity, at one concentration (the size of the read-out at that concentration, not a potency): -98%
Beside the measured number, compound 4's estimate is 18 percentage points above it; the measured number falls inside the stated range.
By their numbers in this assay, from the lowest: compounds 2 and 4 (each within the scatter of the next); then compound 3; then compound 1.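

In this assay, hydrogen can replace methoxy at this aromatic carbon, meta to a large group and ortho to a methoxy group, with no change at the digits printed from compound 2 to compound 4 (within the scatter). The same kind of exchange is not silent everywhere: methoxy in place of hydrogen gives a number 38 percentage points lower from compound 1 to compound 4 (beyond the scatter), so one methoxy exchange moves the read-out while the other does not. Nothing at hand bears on why these two steps differ. From the compounds shown here alone, it remains open whether a hydroxy group, an ethoxy group or fluorine at this carbon would match methoxy or hydrogen.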